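Bromo for methoxy on the aryl ring of compound 1

The source may hold more compounds than are shown below. What is called first, only, known or untested is meant among the compounds shown, and "the series" means these compounds.

Compound 1 `COc1ccc(/C(Cl)=C/C=C(\C#N)C(=O)c2c(C)[nH]c3ccccc23)cc1` gives 56700 nM in a functional assay on MCF7 cells (Homo sapiens) for cytotoxicity, read by sulforhodamine B assay, with a stated time of 48 h; a lower number here means a stronger inhibitor of growth, a higher number a weaker inhibitor of growth. Among the two numbers measured so far it has the highest, and its nearest neighbour is compound 2 `COc1ccc(/C(Cl)=C/C=C(\C#N)C(=O)c2c(C)[nH]c3ccccc23)cc1OC`, which in this assay gives 29600 nM; the step of a 1.9-fold lower number from compound 1 to compound 2 (0.28 log units; within the scatter) stays within the usual scatter. Compound 3 `Cc1[nH]c2ccccc2c1C(=O)/C(C#N)=C/C=C(\Cl)c1ccc(Br)cc1` is the next compound to be run. Relative to compound 1 it carries bromo in place of methoxy on an aromatic carbon. Among the measured compounds shown here, the single measured step, from compound 1 to compound 2, concerns an added methoxy and not the exchange of one substituent for another, so no measured step bears directly on this change. With nothing beyond that to go on, no step beyond the scatter is expected for compound 3 in this assay, giving an expected 1.1-fold lower number from compound 1 to compound 3 (0.05 log units; within the scatter). The estimate for compound 3 is 50000 nM, with a range from 15000 nM to 150000 nM.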

Compound 3, concentration for 50% growth inhibition: 73900 nM
Compound 3: middle estimate off by 1.5-fold (0.17 log units), on the low side; the range from low to high includes it.
By their numbers in this assay, from the lowest: compounds 2, 1 and 3 (each within the scatter of the next, the first and the last beyond it).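

In this assay, among the compounds shown here, the exchange of 4-methoxyphenyl for 4-bromophenyl is the first replacement read at this position, and it gives a 1.3-fold higher number from compound 1 to compound 3 (0.12 log units; within the scatter) as its step. On this one pair, the methoxy on the aromatic carbon can give way to bromo, a group with no oxygen and no hydrogen-bond acceptor, without the number leaving the scatter around compound 1. Nothing measured on these compounds offers an explanation for how closely the two groups read.

From the compounds shown here alone, whether an amine, a carboxylic acid or a longer alkoxy chain at this place would produce a step beyond the scatter remains open. Also open, going by these compounds, is whether bromo in place of methoxy would read the same way on the dimethoxy-substituted ring of compound 2.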